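A few compounds are considered here, and "the series" means these few. Any claim that something is new, unique, unknown or untested is made for them only; others in the source may bear on it.

Compound 1 `Cc1ccc(Oc2ccc(C#N)cc2S(=O)(=O)NC(=O)NC(C)(C)C)cc1`: 680 nM
Compound 2 `CC(C)NC(=O)NS(=O)(=O)c1cc(C#N)ccc1Oc1ccc(F)cc1`: 9300 nM
Compound 3 `CC(C)(C)NC(=O)NS(=O)(=O)c1cc(C#N)ccc1Oc1ccc(F)cc1`: 3890 nM

All three numbers come from a functional assay on HEK293 cells for antagonist activity at thromboxane A2 receptor (Homo sapiens), read by fluorescence and calcium flux; a higher number here means a weaker inhibitor, a lower number a stronger inhibitor. Compound 3 stands second highest of the three; the nearest is compound 2 at 9300 nM, the furthest is compound 1 at 680 nM. Two measured steps lead into compound 3: a 2.4-fold lower number from compound 2 to compound 3 (0.38 log units; beyond the scatter) and a 5.7-fold higher number from compound 1 to compound 3 (0.76 log units; beyond the scatter).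

Compound 4 `Cc1ccc(Nc2ccc(C#N)cc2S(=O)(=O)NC(=O)NC(C)(C)C)cc1` is not yet measured; against compound 3 it carries (4-methylphenyl)amino in place of 4-fluorophenoxy on an aromatic carbon. Of the measured steps only a 5.7-fold higher number from compound 1 to compound 3 (0.76 log units; beyond the scatter) bears on this change, through its fluoro-for-methyl part on the pendant ring; run in reverse it points to a lower number, back toward compound 1. For the measured compounds named here, the second part of the change, the amino linkage in place of the phenoxy linkage, has no measured counterpart, so the expectation leans on the methyl part alone and is held wide. Compound 4 is therefore expected to show a 4.3-fold lower number from compound 3 to compound 4 (0.64 log units; beyond the scatter) in this assay. The estimate for compound 4 is 900 nM, within 250 nM to 3500 nM.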

Compound 4, half-maximal inhibitory concentration: 1040 nM
Estimate against measurement, compound 4: 1.2-fold (0.06 log units) below; low and high end bracket the measured number.
By their numbers in this assay, from the lowest: compounds 1 and 4 (each within the scatter of the next); then compound 3; then compound 2.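

In this assay, for the compounds shown here, the linkage alone is isolated for the first time, and a 1.5-fold higher number from compound 1 to compound 4 (0.18 log units; within the scatter) shows that (4-methylphenyl)amino and 4-methylphenoxy cannot be told apart on this aromatic carbon para to a cyano group, even though the former brings a hydrogen-bond donor. The larger change, a 3.7-fold lower number from compound 3 to compound 4 (0.57 log units; beyond the scatter), alters both the linkage and the ring substituent, and with the linkage step within the scatter, it follows the methyl-versus-fluoro difference between compound 1 and compound 3. No supporting evidence is available to explain either step.

On these data alone, whether a methylene or thioether linkage would be tolerated as well as the oxygen and amino linkages remains open. So does whether a chloro or methoxy group on the pendant ring would match methyl.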